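This account rests on a few compounds, and the source may have more. Where it says the series, first, only, none or still open, it means among the compounds named here.

Measured compounds:
compound 1 `COc1ccc(N(CC(=O)NCCCSc2ccccc2)C(=O)/C=C/c2ccccc2)cc1` — >= 100000 nM in an ADME assay on cells (Fibroblast, Homo sapiens) for cytotoxicity, read by MTT assay, with a stated time of 24 h; on this read-out lower numbers stand for stronger inhibition and higher numbers for weaker inhibition
compound 2 `COc1ccc(N(CC(=O)NCCC[Se]c2ccccc2)C(=O)C#Cc2ccccc2)cc1` — >= 100000 nM in this assay

Both numbers shown are limits of this assay rather than measured figures. Compound 1 gives >= 100000 nM in this assay, which is a limit. Compound 2 likewise gives >= 100000 nM in this assay, again a limit. Compound 2 therefore stands where every value shown stands: at the limit, alongside compound 1 (the limit of >= 100000 nM in this assay, at which 2 of the 2 values shown sit).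

The unmeasured compound 3 `COc1ccc(N(CC(=O)NCCCSc2ccccc2)C(=O)C#Cc2ccccc2)cc1` differs from compound 2 in one place: a group of 7 heavy atoms (6 carbon, 1 sulfur; one six-membered aromatic ring of carbon only) in place of a group of 7 heavy atoms (6 carbon, 1 selenium; one six-membered aromatic ring of carbon only), on a saturated chain carbon, three bonds along the chain from an amide-type nitrogen. Compound 1 already carries the phenylsulfanyl group at this place and sits at the same limit as compound 2, so no step beyond the scatter is expected from compound 2 to compound 3 in this assay. The estimated step from compound 2 to compound 3 is a number no higher from compound 2 to compound 3 (the limit leaves the size open).

Compound 3 is thus expected to give about 100000 nM in this assay, within a range from 50000 nM to 200000 nM, most likely again reported as a limit.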

Compound 3, half-maximal inhibitory concentration: >= 100000 nM
Compound 3 ended at the assay's limit; the forecaster's own chance of this, stated with the estimate: 85%; the middle value sits exactly at the limit.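

Compound 3 gives >= 100000 nM in this assay, which is a limit. The steps to compound 3 from compound 1 and from compound 2 cannot be read: the limit of >= 100000 nM in this assay, at which 3 of the 3 values shown sit.

The compounds shown leave open what real values lie behind this limit, and whether either single change alters the read-out in this assay.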